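The source may report more compounds than this note shows. Statements on the series, on what has been measured and on what is new or still open speak of the compounds shown alone.

Compound 1, `CCCCNC(=O)Oc1ccc(C(=O)OC)cc1`: 35%
Compound 2, `COC(=O)c1ccc(OC(=O)NC2CCCCC2)cc1`: 41%

In an assay on cell membranes (strain Wistar) for inhibition of Fatty-acid amide hydrolase 1 (Rattus norvegicus), read by scintillation counting, tested at 0.1 uM (on this read-out higher numbers stand for more inhibition at the one concentration tested (going by the name of the read-out) and lower numbers for less inhibition), compound 1 gives 35%. For the measured compounds named here, only one other number is known, that of compound 2 at 41%, and the step of a number 6 percentage points higher from compound 1 to compound 2 (within the scatter) lies within the scatter, so compound 1 cannot be told apart from compound 2 on these numbers; it merely carries the smaller figure of the two.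

Compound 3, `CCCCNC(=O)Oc1ccc([N+](=O)[O-])cc1`, differs from compound 1 in one place: nitro in place of methoxycarbonyl on an aromatic carbon. Going by the values given here, the single measured step, a number 6 percentage points higher from compound 1 to compound 2 (within the scatter), concerns the group on the amide-type nitrogen, not the aromatic carbon where the change to compound 3 occurs, so no measured step bears on this change. With nothing to point either way, the expected step of a number 3 percentage points higher from compound 1 to compound 3 (within the scatter) is none beyond the scatter. Compound 3 is therefore estimated at 38% in this assay, within a range from 15% to 65%.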

Compound 3, a percentage reported as inhibition, at one concentration (the size of the read-out at that concentration, not a potency): 16%
For compound 3 the middle estimate is 22 percentage points above the measured one; measured number inside the range.
By their numbers in this assay, from the lowest: compound 3; then compounds 1 and 2 (each within the scatter of the next).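

Placing nitro instead of methoxycarbonyl on the aromatic carbon, para to a group of 8 heavy atoms, gives the first change beyond the scatter in this assay: a number 19 percentage points lower from compound 1 to compound 3 (beyond the scatter). The earlier step, on the amide-type nitrogen, could not separate its two compounds, whereas this aromatic position does respond to a change of group, even though both groups have the same counted hydrogen-bond donors and acceptors and no net charge. Nothing available explains why the number falls with this change.

From the compounds shown here alone, whether nitro gives a similar step with cyclohexyl on the amide-type nitrogen remains open. Also open, going by these compounds, is how an amine, a carboxylic acid or a nitrile on this aromatic carbon, or a longer chain on that nitrogen, would read in this assay.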